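The source may hold more compounds than are shown below. What is called first, only, known or untested is meant among the compounds shown, and "the series" means these compounds.

- Compound 1 `CC(=O)N1CCCC([C@@H]2[C@@H](C(=O)Nc3ccc(F)c(C#N)c3)c3ccccc3C(=O)N2CC(C)C)C1`: 69000 nM
- Compound 2 `Cc1ccc([C@@H]2[C@@H](C(=O)Nc3ccc(F)c(C#N)c3)c3ccccc3C(=O)N2CC(C)C)s1`: < 1000 nM (a limit of the assay, not a number)
- Compound 3 `CC(C)CN1C(=O)c2ccccc2[C@H](C(=O)Nc2ccc(F)c(C#N)c2)[C@H]1c1cnsc1`: 20000 nM

These three compounds share one core and differ only in the group on a saturated ring carbon. All were tested in a physicochemical assay for solubility, in phosphate buffer, with a stated time of 18 h, at pH 7; on this read-out higher numbers stand for higher solubility and lower numbers for lower solubility. Compound 2 gave only a limit, < 1000 nM. That leaves two true numbers, and compound 3 has the lower of them, with a 3.5-fold lower number from compound 1 to compound 3 (0.54 log units; beyond the scatter).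

Compound 4 `CC(C)CN1C(=O)c2ccccc2[C@H](C(=O)Nc2ccc(F)c(C#N)c2)[C@H]1c1csnn1` has not yet been measured. Its structure carries 1,2,3-thiadiazol-4-yl in place of 1,2-thiazol-4-yl on a saturated ring carbon. The new group sits on the same carbon, next to the ring nitrogen.

Three measured steps changed this same group. The modest one is a 3.5-fold lower number from compound 1 to compound 3 (0.54 log units; beyond the scatter), and the two large ones are an at least 69-fold lower number from compound 1 to compound 2 (1.83 log units; beyond the scatter) and an at least 20-fold higher number from compound 2 to compound 3 (1.30 log units; beyond the scatter). So this position can matter a great deal in this assay. However, those swaps replaced one group with a clearly different one, whereas here the ring size stays the same and one ring carbon becomes nitrogen. None of the steps tests this exact swap, so the estimate rests on compound 3 at 20000 nM, and the range is kept wide. No change beyond the scatter is expected, and the estimated step is a 1.3-fold higher number from compound 3 to compound 4 (0.10 log units; within the scatter). For compound 4 the expected value is 25000 nM, with an estimated range of 8000 nM to 70000 nM.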

Compound 4, solubility: 5000 nM
Beside the measured number, compound 4's estimate is 5.0-fold (0.70 log units) above it; the measured number lies below the stated range.
By their numbers in this assay, from the lowest: compound 4; then compound 3; then compound 1. At a limit, below all of these: compound 2.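

In this assay, this position turns out to respond even to a small edit: with the ring size unchanged and one ring carbon becoming nitrogen, 1,2,3-thiadiazol-4-yl in place of 1,2-thiazol-4-yl gives a 4.0-fold lower number from compound 3 to compound 4 (0.60 log units; beyond the scatter), whereas every earlier step had swapped one group for a clearly different one. Replacing the non-aromatic 1-acetylpiperidin-3-yl group with the new ring gives a 14-fold lower number from compound 1 to compound 4 (1.14 log units; beyond the scatter), a large step rather than the modest one seen with 1,2-thiazol-4-yl. Compound 2 holds only a limit of the assay, so the comparison with it reads as an at least 5.0-fold higher number from compound 2 to compound 4 (0.69 log units; beyond the scatter), and its true size stays unknown: the limit of < 1000 nM in this assay, at which 1 of the 4 values shown sits.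

The compounds shown leave open whether adding a ring nitrogen would lower the number on other aromatic rings at this position, as this is the only pair that tests such a change. Also open, on these data alone, is how this assay would read with a primary amine or a carboxylic acid on this saturated ring carbon, or with a non-aromatic ring other than 1-acetylpiperidin-3-yl.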